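The compounds below may be only part of what the source reports. "The series", "measured", "known", "first", "only" and "open" are said of these compounds alone.

Measured compounds in a functional assay on PC-3 cells (Homo sapiens) for cytotoxicity, read by MTT assay, with a stated time of 48 h; on this read-out lower numbers stand for stronger inhibition and higher numbers for weaker inhibition:
compound 1 `O=C(c1ccccc1Cl)N1N=C(c2cc3ccccc3oc2=O)CC1c1ccccc1`: 6370 nM
compound 2 `CC1CC(C)CN(CC(=O)N2N=C(c3cc4ccccc4oc3=O)CC2c2ccccc2)C1`: "not active" (no number reported)
compound 3 `CCN(CC)C1CCN(CC(=O)N2N=C(c3cc4ccccc4oc3=O)CC2c2ccccc2)CC1`: 26100 nM

Compound 3 holds the highest of the two numbers in this assay; its nearest neighbour is compound 1, and the step of a 4.1-fold higher number from compound 1 to compound 3 (0.61 log units; beyond the scatter) is beyond the scatter. Compound 2, which carries a dimethylpiperidinyl chain on the same carbonyl, returned no number at all in this assay.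

Compound 4 `CN1CCN(CC(=O)N2N=C(c3cc4ccccc4oc3=O)CC2c2ccccc2)CC1` differs from compound 3 in one place: 4-methylpiperazin-1-yl in place of 4-(diethylamino)piperidin-1-yl on a saturated chain carbon bound to a carbonyl carbon. For the measured compounds named here, only one measured step bears on this, the exchange of an aryl group for an amine-bearing chain from compound 1 to compound 3, which raised the number modestly. The step from compound 3 to compound 4 is a swap between two such chains, so it is a smaller change than the one already measured, while compound 2 shows that a third chain of this kind gave no measurable number.

Compound 4 is therefore expected to stay close to compound 3 or to weaken somewhat, with a real chance of no reported number. Compound 4 is estimated at 35000 nM, within 12000 nM to 100000 nM. The expected step of a 1.3-fold higher number from compound 3 to compound 4 (0.13 log units; within the scatter) is small and may not exceed the scatter.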

Compound 4, half-maximal inhibitory concentration: 25800 nM
Compound 4: middle estimate off by 1.4-fold (0.13 log units), on the high side, within the range that was stated.
By their numbers in this assay, from the lowest: compound 1; then compounds 4 and 3 (each within the scatter of the next).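

In this assay, the exchange of 4-(diethylamino)piperidin-1-yl for 4-methylpiperazin-1-yl on a saturated chain carbon bound to a carbonyl carbon gives a step within the scatter (a 1.0-fold lower number from compound 3 to compound 4 (0.01 log units; within the scatter)), so at this position a change from 11 heavy atoms to 7, with a second ring hetero atom in place of the diethylamino nitrogen, has no readable effect on the number. The gap to the 2-chlorophenyl amide compound 1 now rests on two amine chains rather than one: (a 4.1-fold higher number from compound 1 to compound 4 (0.61 log units; beyond the scatter)) stands with the earlier (a 4.1-fold higher number from compound 1 to compound 3 (0.61 log units; beyond the scatter)), and both are beyond the scatter and modest in size. Nothing measured here bears on why the two chains read alike.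

Compound 2 gives no number, so its steps to the other compounds cannot be read, and it stands apart from compound 3 and compound 4 without any measure of how far. Open, as far as these compounds go, is whether a morpholin-4-yl ring, a longer chain to the amine, or a carboxylic acid on the same carbon would stay with compound 3 and compound 4 or come closer to compound 1.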